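The compounds below may be only part of what the source reports. "The series", "measured", "known", "first", "only" and "open" are said of these compounds alone.

Measured compounds and values:
- compound 1, `Cc1ccc(OCC(=O)N(Cc2cccs2)c2ccnn2C)cc1`: 422 nM
- compound 2, `Cc1ccc(OCC(=O)N(CCO)Cc2cccs2)cc1`: 900 nM
- compound 3, `Cc1ccc(OCC(=O)N(C)Cc2cccs2)cc1`: 400 nM

All three share one core and differ only in the group carried on the amide-type nitrogen. In an assay on HEK293 cells for agonist activity at transient receptor potential cation channel subfamily M member 8 (Homo sapiens), read by fluorescence and calcium flux, with a stated time of 15 min (on this read-out higher numbers stand for an effect only at larger amounts of compound and lower numbers for an effect already at smaller amounts), compound 3 gives the lowest of the three numbers, though its gap to compound 1 is within the scatter, so the two cannot be ranked against each other; only compound 2 stands apart, at 900 nM.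

The next compound, compound 4, `Cc1ccc(OCC(=O)N(Cc2cccs2)c2ccccn2)cc1`, is not yet measured. It differs from compound 3 in one place: pyridin-2-yl in place of methyl on an amide-type nitrogen.

Among the measured compounds shown here, two measured steps bear on this. The closest comparison is a 1.1-fold lower number from compound 1 to compound 3 (0.02 log units; within the scatter), which shows that exchanging methyl for a small aromatic ring at this nitrogen left the number essentially unchanged. The other step, a 2.1-fold higher number from compound 1 to compound 2 (0.33 log units; beyond the scatter), and likewise a 2.3-fold lower number from compound 2 to compound 3 (0.35 log units; beyond the scatter), show that only the 2-hydroxyethyl group shifted the number, and only modestly. Since compound 4 again places an aromatic ring where compound 3 has methyl, no step beyond the scatter is expected in this assay, with a 1.1-fold higher number from compound 3 to compound 4 (0.05 log units; within the scatter) as the expected movement.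

Compound 4 is therefore estimated at about 450 nM in this assay, with a likely range from 200 nM to 1000 nM.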

Compound 4, half-maximal effective concentration: 200 nM
Compound 4: the middle estimate sits 2.3-fold (0.35 log units) above what was measured; measured number inside the range.
By their numbers in this assay, from the lowest: compounds 4, 3 and 1 (each within the scatter of the next, the first and the last beyond it); then compound 2.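

In this assay, pyridin-2-yl on the amide-type nitrogen gives a 2.0-fold lower number from compound 3 to compound 4 (0.30 log units; within the scatter), so this ring, like 1-methyl-1H-pyrazol-5-yl before it, cannot be told apart from methyl at this position. Among the compounds shown here, what is new is that two aromatic rings at the same nitrogen can now be told apart: a 2.1-fold lower number from compound 1 to compound 4 (0.32 log units; beyond the scatter) is the first ring-for-ring exchange in the set, and it lies beyond the scatter, though the step is modest. Compound 2, with its 2-hydroxyethyl group, remains at the high end of the series, and a 4.5-fold lower number from compound 2 to compound 4 (0.65 log units; beyond the scatter) is the widest gap seen so far. Nothing in the data shown explains why these groups differ.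

On these data alone, what phenyl, the same ring with carbon in place of the ring nitrogen, would give at this position stays open, as does the effect of a longer chain ending in an amine or a carboxylic acid. As far as these compounds go, every compound here keeps the rest of the shared core fixed, and whether the difference between the two rings would persist on a different core also stays open.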